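Swapping the aryl group while keeping the nitro group

This account rests on a few compounds, and the source may have more. Where it says the series, first, only, none or still open, it means among the compounds named here.

Values measured in a functional assay on A549 cells (Homo sapiens) for antiproliferative activity, read by MTT assay; on this read-out higher numbers stand for weaker inhibition and lower numbers for stronger inhibition
- compound 1 `COc1ccc(-c2ccnc(Nc3ccc([N+](=O)[O-])cc3)n2)cc1` gives 2730 nM
- compound 2 `Clc1ccc(Nc2nccc(-c3ccc(Cl)cc3Cl)n2)c(Cl)c1` gives 11600 nM
- compound 3 `COc1ccc(-c2ccnc(Nc3ccc(Cl)cc3)n2)cc1` gives 20900 nM

Compound 1 has the lowest number of the three. The next compound to consider is compound 4 `O=[N+]([O-])c1ccc(Nc2nccc(-c3ccc(Cl)cc3Cl)n2)cc1`, which has not been measured. The change from compound 1 is 2,4-dichlorophenyl in place of 4-methoxyphenyl on an aromatic carbon and amounts to 2,4-dichlorophenyl in place of 4-methoxyphenyl on an aromatic carbon.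

Within the data shown here, no measured step covers this change directly. The only one is a 7.7-fold higher number from compound 1 to compound 3 (0.88 log units; beyond the scatter) and lies beyond the scatter, but it is chloro in place of nitro, a change compound 4 does not make. Compound 2 at 11600 nM carries the incoming group and compound 3 at 20900 nM the outgoing one, yet this pair also differs in a second place and cannot isolate the swap.

In this assay no step beyond the scatter is therefore expected, in either direction. The expected result is a 1.1-fold lower number from compound 1 to compound 4 (0.04 log units; within the scatter) in size, with wide uncertainty. Compound 4 is estimated at 2500 nM with an expected range of 800 nM to 8000 nM for repeat measurements.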

Compound 4, half-maximal inhibitory concentration: 119000 nM
Compound 4: the middle estimate sits 48-fold (1.68 log units) below what was measured; measured number above the stated range.
By their numbers in this assay, from the lowest: compound 1; then compounds 2 and 3 (each within the scatter of the next); then compound 4.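

With the nitro group held constant, the aryl group on the aromatic carbon next to the ring nitrogen strongly affects the read-out in this assay: 2,4-dichlorophenyl in place of 4-methoxyphenyl gives a 44-fold higher number from compound 1 to compound 4 (1.64 log units; beyond the scatter). Among these compounds, the earlier step, chloro in place of nitro, spoke only to the other aryl group, so this is the first direct reading at this position. No measurement on hand accounts for the step.

This single swap removes the methoxy group and adds two chlorines, so the compounds shown leave open which of these changes carries the step. Plain phenyl, 4-chlorophenyl and 4-aminophenyl at this position, each with the nitro group kept, would help separate those contributions.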